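From fluoro to chloro in a small series

A few compounds are considered here, and "the series" means these few. Any claim that something is new, unique, unknown or untested is made for them only; others in the source may bear on it.

Measured so far in a functional assay on LNCaP cells (Homo sapiens) for cytotoxicity, read by MTT assay; on this read-out lower numbers stand for stronger inhibition and higher numbers for weaker inhibition
Compound 1 `COc1cccc(CSc2nnc([C@@H](C)c3ccc4cc(OC)ccc4c3)n2-c2ccc(Cl)cc2)c1` gives 162000 nM
Compound 2 `COc1ccc2cc([C@H](C)c3nnc(SCc4c(Cl)cccc4Cl)n3-c3ccc(F)cc3)ccc2c1` gives 12300 nM

Compound 2 has the lower of the two numbers, and its gap to compound 1 lies beyond the usual scatter. Compound 3 `COc1ccc2cc([C@H](C)c3nnc(SCc4c(Cl)cccc4Cl)n3-c3ccc(Cl)cc3)ccc2c1` differs from compound 2 in one place (chloro in place of fluoro on an aromatic carbon), with chloro in place of fluoro on an aromatic carbon. Among the compounds with values here, no measured pair shows this swap, so the data offer no direct guide. The expected step (a 1.2-fold lower number from compound 2 to compound 3 (0.09 log units; within the scatter)) is small, within the scatter and without a firm direction. Compound 3 is estimated at 10000 nM in this assay (range 3500 nM to 30000 nM).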

Compound 3, half-maximal inhibitory concentration: > 400000 nM
Compound 3 was reported as a limit; the forecaster's own chance of this, stated with the estimate: 5%; middle value at least 40-fold (1.60 log units) away from the limit.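

Chloro in place of fluoro looks like a minimal swap on the aromatic ring, yet here it is far from neutral: an at least 32-fold higher number from compound 2 to compound 3 (1.51 log units; beyond the scatter). With 4-chlorophenyl kept, the group on the sulfur-bound chain also matters, as 2,6-dichlorophenyl in place of 3-methoxyphenyl gives an at least 2.4-fold higher number from compound 1 to compound 3 (0.39 log units; beyond the scatter). The value of compound 3 is a limit, not a number: the limit of > 400000 nM in this assay, at which 1 of the 3 values shown sits.

On these data alone, what a bromo, a nitrile or a plain hydrogen would do in the same place remains open. So does whether fluoro would bring a similar gain alongside 3-methoxyphenyl.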